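The source may report more compounds than this note shows. Statements on the series, on what has been measured and on what is new or still open speak of the compounds shown alone.

Measured so far:

Compound 1 `Cc1ccc(C)n1-c1ccc2c(c1)C(n1ccccc1=O)=CC(C)(C)O2`, which in a functional assay (aorta) with Rattus norvegicus as the target (a lower number here means a less potent compound, a higher number a more potent compound, by a factor of ten per unit of this negative logarithm), gives 7.27.
Compound 2 `CC(=O)Oc1ccc2c(c1)C(n1ccccc1=O)=CC(C)(C)O2`, which in this assay gives 5.6.
Compound 3 `CC1(C)C=C(n2ccccc2=O)c2cc(OS(=O)(=O)F)ccc2O1`, which in this assay gives 7.95.

Compound 3 stands highest of the three: compound 1 is nearest, lying a number 0.68 log units higher from compound 1 to compound 3 (beyond the scatter) away when read from compound 1, and compound 2 is furthest, with a number 2.35 log units higher from compound 2 to compound 3 (beyond the scatter).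

Compound 4 `CC1(C)C=C(n2ccccc2=O)c2cc(C(=N)S)ccc2O1` has not yet been measured. It differs from compound 3 at the same place where the three measured compounds already differ from one another: a group of 3 heavy atoms (1 carbon, 1 nitrogen, 1 sulfur; no ring) in place of a group of 5 heavy atoms (3 oxygen, 1 fluorine, 1 sulfur; no ring), on an aromatic carbon.

Within the data shown here, two measured steps bear on this. Exchanging the group at this position gave a number 0.68 log units higher from compound 1 to compound 3 (beyond the scatter) and a number 2.35 log units higher from compound 2 to compound 3 (beyond the scatter), so a change here can move the number a great deal, and compound 3 carries the group that gave the highest value seen. Since the entering group resembles none of the three measured ones, the direction is uncertain, but a step of some size in this assay is expected, most likely downward, a number 0.95 log units lower from compound 3 to compound 4 (beyond the scatter). Compound 4 is therefore estimated at 7, with a range from 6 to 8.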

Compound 4, logarithm of the reciprocal of the active concentration, log(1/C): 6.21
The estimate for compound 4 lay 0.79 log units above the measured number, and the stated range covers the measured number.
By their numbers in this assay, from the lowest: compound 2; then compound 4; then compound 1; then compound 3.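

In this assay, the group on this aromatic carbon in compound 4 gives an intermediate result: a number 0.61 log units higher from compound 2 to compound 4 (beyond the scatter), whereas a number 1.06 log units lower from compound 1 to compound 4 (beyond the scatter) and a number 1.74 log units lower from compound 3 to compound 4 (beyond the scatter). The size of the group does not follow this order, since the group in compound 4 has the fewest heavy atoms of the four, yet compound 4 stands above the acetoxy compound 2 and below compound 1, which has the largest group, and compound 3. Nothing measured here explains why the groups rank this way.

The compounds shown leave open how a simple amine or a carboxylic acid on this carbon would compare with the (fluorosulfonyl)oxy group of compound 3. They also leave open whether a nitrile or a plain amide would fall closer to compound 3 or to compound 2.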